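The source may hold more compounds than are shown below. What is called first, only, known or untested is meant among the compounds shown, and "the series" means these compounds.

Measured so far in a functional assay on EL4 cells (Mus musculus) for inhibition, tested at 100 uM; on this read-out higher numbers stand for more inhibition at the one concentration tested (going by the name of the read-out) and lower numbers for less inhibition:
- compound 1 `[N-]=[N+]=Nc1nccc2c1ncn2[C@H]1C[C@H](O)[C@@H](CO)O1`: 13%
- compound 2 `Nc1nccc2c1ncn2[C@H]1C[C@H](O)[C@@H](CO)O1`: 89%
- compound 3 `CN(C)c1nccc2c1ncn2[C@H]1C[C@H](O)[C@@H](CO)O1`: < 5%

Compound 3 sits at the floor of this assay; its value is a limit, not a number (the limit of < 5% in this assay, at which 1 of the 3 values shown sits). Compound 4 `OC[C@H]1O[C@@H](n2cnc3c(Cl)nccc32)C[C@@H]1O` differs from compound 3 as chloro in place of dimethylamino on an aromatic carbon. Among the compounds with values here, no measured step puts chloro in place of any group, so the only bearing comes from the steps that bring dimethylamino in: a number at least 8 percentage points lower from compound 1 to compound 3 (that floor lies within the scatter) and a number at least 84 percentage points lower from compound 2 to compound 3 (beyond the scatter). Both fell when dimethylamino entered, the second one sharply; taking it away again points upward, but by how much is not fixed, since azido and amino differ widely from one another. For compound 4 the expected step is a number at least 13 percentage points higher from compound 3 to compound 4 (beyond the scatter), a modest rise off the floor. Compound 4 is estimated at 18%, within 5% to 45%.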

Compound 4, a percentage reported as inhibition, at one concentration (the size of the read-out at that concentration, not a potency): < 5%
Compound 4 was reported as a limit (the forecaster's own chance of this, stated with the estimate: 25%); middle value at least 13 percentage points from the limit.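

In this assay, chloro on this aromatic carbon is a second replacement of amino that leaves the read-out at the floor, giving a number at least 84 percentage points lower from compound 2 to compound 4 (beyond the scatter). Against azido the change gives a number at least 8 percentage points lower from compound 1 to compound 4 (that floor lies within the scatter), and the step between compound 3 and compound 4 cannot be read, as both values are limits. The floor now holds compound 3 and compound 4: the limit of < 5% in this assay, at which 2 of the 4 values shown sit.

Chloro and dimethylamino cannot be ranked against each other. From the compounds shown here alone, whether methylamino or hydroxyl at this position keeps any of the inhibition seen with amino remains open.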